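Sulfonamide-bearing analogue of an inactive pyrazolyl anilinopyrimidinone

The compounds below may be only part of what the source reports. "The series", "measured", "known", "first", "only" and "open" are said of these compounds alone.

Working notes on a small pyrimidinone set. Compound 1 `CC[C@@H]1C(=O)N(C)c2cnc(-n3ccc4cc(C(N)=O)ccc43)nc2N1C1CCCC1` carries an indolyl carboxamide and a cyclopentyl group on the shared core, and in a functional assay on MCF7 cells (Homo sapiens) for antiproliferative activity, read by CCK-8 assay, with a stated time of 72 h (on this read-out higher numbers stand for weaker inhibition of growth and lower numbers for stronger inhibition of growth), compound 1 gives 1830 nM. Compound 2 `CCC1C(=O)N(C)c2cnc(Nc3ccc(S(=O)(=O)NCCO)cc3)nc2N1c1ccn(C)n1` swaps both for a methylpyrazolyl group and an anilino substituent bearing a (2-hydroxyethyl)sulfamoyl group; in this assay compound 2 is reported as "not active" (no number reported), a qualitative outcome with no number attached, so compound 2 stands outside the numerical scale on which compound 1 sits, and nothing beyond that ordering can be read from the pair.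

Compound 3 `CCC1C(=O)N(C)c2cnc(Nc3ccc(S(N)(=O)=O)cc3)nc2N1c1ccn(C)n1` is the close relative of compound 2, differing only by hydrogen in place of 2-hydroxyethyl on a sulfonamide nitrogen. Among the measured compounds shown here, with no measured step for this change, the working expectation for this assay is a shift of no more than the usual scatter in either direction, leaving compound 3 near the weak end where compound 2 sits.

On that basis compound 3 is estimated at 20000 nM, with a plausible range from 3000 nM to 100000 nM, and a substantial chance that only an inactive call is returned.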

Compound 3, concentration for 50% growth inhibition: 36600 nM
Compound 3: the middle estimate sits 1.8-fold (0.26 log units) below what was measured; the measured number falls inside the stated range.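

No step can be read between compound 2 and compound 3: in this assay compound 2 has only a "not active" call with no number, whereas compound 3 gives 36600 nM on the numerical scale. No evidence bears on a cause for this result. The compounds shown leave open how large a change in growth inhibition goes with replacing 2-hydroxyethyl by hydrogen on the sulfonamide nitrogen.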